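This account rests on a few compounds, and the source may have more. Where it says the series, first, only, none or still open, it means among the compounds named here.

In a functional assay on A549 cells (Homo sapiens) for antiproliferative activity, read by CCK-8 assay, with a stated time of 72 h (a higher number here means a weaker inhibitor of growth, a lower number a stronger inhibitor of growth), compound 2 `CC[C@@H]1C(=O)N(C)c2cnc(-n3ccc4ccccc43)nc2N1C1CCCC1` gives 57500 nM as the highest of the three numbers measured. Compound 1 `CCCNS(=O)(=O)c1ccc(Nc2ncc3c(n2)N(c2ccn(C)n2)C(CC)C(=O)N3C)cc1` gives 15000 nM and compound 3 `CCCCNS(=O)(=O)c1ccc(Nc2ncc3c(n2)N(c2ccn(C)n2)C(CC)C(=O)N3C)cc1` gives 10600 nM on a different core, and both lie beyond the scatter from compound 2 on the lower side. Compound 4 `CC[C@@H]1C(=O)N(C)c2cnc(-n3ccc4cc(C(=O)NCC(C)C)ccc43)nc2N1C1CCCC1` alters compound 2 in one place, with isobutylcarbamoyl in place of hydrogen on an aromatic carbon is the whole difference. Among the compounds with values here, the only measured step, a 1.4-fold lower number from compound 1 to compound 3 (0.15 log units; within the scatter) for methyl in place of hydrogen on a saturated chain carbon, stays within the scatter and lies on another core, so it bears only weakly on this change. Within the data shown here, no measured pair adds a group at this place. Compound 3 at 10600 nM does carry a side chain and sits lower than compound 2, but the two differ in more than that. A modest move to a lower number in this assay is therefore expected, though it may not clear the scatter. The expected step is a 2.3-fold lower number from compound 2 to compound 4 (0.36 log units; beyond the scatter) with wide uncertainty. Compound 4 is estimated at 25000 nM with an expected range from 7000 nM to 70000 nM in this estimate.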

Compound 4, concentration for 50% growth inhibition: 1730 nM
For compound 4 the middle estimate is 14-fold (1.16 log units) above the measured one; the whole stated range lies above it.
By their numbers in this assay, from the lowest: compound 4; then compounds 3 and 1 (each within the scatter of the next); then compound 2.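

In this assay, the aromatic carbon on the six-membered ring of carbon only proves sensitive to substitution: isobutylcarbamoyl in place of hydrogen gives a 33-fold lower number from compound 2 to compound 4 (1.52 log units; beyond the scatter). Within the data shown here, the earlier compounds held no pair changed at this place, and their one step, on another core and at a saturated chain carbon, stayed within the scatter, so this is the first sign that a single change can move the number substantially. No measured evidence accounts for the size of this step.

The compounds shown leave open whether the carbonyl with its amide hydrogen or the isobutyl chain carries the step, which a carboxylic acid, an unsubstituted carboxamide or a methylcarbamoyl group at this place could separate. They also leave open whether an amine or a longer chain on the amide nitrogen would go further.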